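Halogen placement on the phenyl ring of the shared core

The source may report more compounds than this note shows. Statements on the series, on what has been measured and on what is new or still open speak of the compounds shown alone.

For the measured compounds named here, in an assay on isolated protein for inhibition of Amine oxidase [flavin-containing] B (Homo sapiens), read by fluorescence, with a stated time of 1 h, tested at 10 uM (on this read-out lower numbers stand for less inhibition and higher numbers for more inhibition at the one concentration tested (going by the name of the read-out)), compound 2 `Fc1ccc(-c2nc3ccc(N4CCCCC4)nc3s2)cc1` gives 92.7%, the lowest of the two numbers so far; the nearest is compound 1 `c1ccc(-c2nc3ccc(N4CCCCC4)nc3s2)cc1` with 95.5%, and the only measured step is a number 2.8 percentage points lower from compound 1 to compound 2 (within the scatter). Compound 3 `Clc1ccccc1-c1nc2ccc(N3CCCCC3)nc2s1` is not yet measured and differs from compound 2 by 2-chlorophenyl in place of 4-fluorophenyl on an aromatic carbon. Going by the values given here, only the step from compound 1 to compound 2 bears on this change, and it stayed within the scatter, so no large move is anticipated. For compound 3 a modest downward step is expected, a number 7.7 percentage points lower from compound 2 to compound 3 (within the scatter), with wide uncertainty since a single step informs it. Compound 3 is therefore estimated at 85%, between 60% and 97%.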

Compound 3, a percentage reported as inhibition, at one concentration (the size of the read-out at that concentration, not a potency): 95.1%
Compound 3: the middle estimate sits 10.1 percentage points below what was measured, within the range that was stated.
By their numbers in this assay, from the lowest: compounds 2, 3 and 1 (each within the scatter of the next).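

In this assay, moving from 4-fluorophenyl to 2-chlorophenyl on the aromatic carbon of the five-membered ring gives a number 2.4 percentage points higher from compound 2 to compound 3 (within the scatter). Chloro in place of hydrogen gives a number 0.4 percentage points lower from compound 1 to compound 3 (within the scatter), so a second halogen and a second ring placement also leave the read-out within the scatter of the unsubstituted phenyl. Nothing at hand accounts for these steps.

All three compounds sit so close at this single concentration that the read-out cannot rank them. As far as these compounds go, whether an amine or a carboxylic acid on the phenyl ring would move the number remains open.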